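The source may report more compounds than this note shows. Statements on the series, on what has been measured and on what is new or still open speak of the compounds shown alone.

Measured so far:
Compound 1 `COc1ccc(-n2cc(COC(=O)c3cc4ccccc4[nH]3)nn2)cc1` — in an ADME assay on HEK293 cells (Homo sapiens) for cytotoxicity, read by MTT assay, with a stated time of 48 h (on this read-out higher numbers stand for weaker inhibition and lower numbers for stronger inhibition), compound 1 gives 42500 nM.
Compound 2 `O=C(OCc1cn(-c2ccccc2Br)nn1)c1cc2ccccc2n1Cc1cn(-c2ccccc2Br)nn1` — in this assay compound 2 gives 12100 nM.

Compound 1 shows the higher of the two numbers, so it stands as the weaker inhibitor of the pair; the gap to compound 2 is beyond the usual scatter of this assay. Among the compounds with values here, no step between two measured compounds that differ in a single place is available, so nothing measured tells how a change on the aromatic nitrogen shifts the number.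

Compound 3 `Cc1cc(C)cc(-n2cc(COC(=O)c3cc4ccccc4[nH]3)nn2)c1` has not yet been measured. It differs from compound 1 in one place: 3,5-dimethylphenyl in place of 4-methoxyphenyl on an aromatic nitrogen. Both groups are of the same size, and the change removes one hydrogen-bond acceptor. Within the data shown here, with no measured step of this kind to lean on, the author expects at most a modest shift, if any, and none clearly beyond the scatter; if a direction is to be named, a slightly lower number is expected from compound 1 to compound 3, as a 1.2-fold lower number from compound 1 to compound 3 (0.08 log units; within the scatter). For compound 3 the author therefore estimates 35000 nM in this assay, with a range from 15000 nM to 80000 nM.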

Compound 3, half-maximal inhibitory concentration: 12500 nM
Compound 3: the middle estimate sits 2.8-fold (0.45 log units) above what was measured, outside the stated range (below it).
By their numbers in this assay, from the lowest: compounds 2 and 3 (each within the scatter of the next); then compound 1.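

In this assay, the change from 4-methoxyphenyl to 3,5-dimethylphenyl on the aromatic nitrogen of the five-membered ring gives a 3.4-fold lower number from compound 1 to compound 3 (0.53 log units; beyond the scatter), the first measured sign that this position responds to its substituent by more than the scatter. The response appears even though the entering and leaving groups both consist of a six-membered aromatic ring of carbon only, with the hydrogen-bond acceptor of the 4-methoxyphenyl group absent from the 3,5-dimethylphenyl group, so a change in the decoration of that ring alone is enough to lower the number. No measured information accounts for this shift.

The compounds shown leave open whether the lower number follows the departure of the methoxy group or the arrival of the two methyl groups, as both changes occur together in this single step. They also leave open how the number would respond to a plain phenyl ring on the same nitrogen, or to an amine or a carboxylic acid carried on that ring.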